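The source may hold more compounds than are shown below. What is called first, only, known or untested is meant among the compounds shown, and "the series" means these compounds.

Measured so far in a functional assay on HCT-116 cells (Homo sapiens) for inhibition, read by CCK-8 assay, with a stated time of 72 h, tested at 2 uM; on this read-out lower numbers stand for less inhibition of growth and higher numbers for more inhibition of growth at the one concentration tested:

Compound 1 `Nc1ccccc1NC(=O)/C=C/c1ccc(CSc2ccc(Cl)cc2)cc1`: 5.62%
Compound 2 `COC(=O)c1ccccc1SCc1ccc(C(=O)Nc2ccccc2N)cc1`: 21.8%

Of these two numbers, compound 1 has the lower, 5.62%, and compound 2 has the higher, 21.8%, and the gap between them lies beyond the usual scatter. The two compounds differ in more than one place, so this gap says nothing about any single change.

Compound 3 `CC(C)(C)c1ccc(SCc2ccc(/C=C/C(=O)Nc3ccccc3N)cc2)cc1` keeps the core of compound 1 and changes one group, with tert-butyl in place of chloro on an aromatic carbon, para to a large group: tert-butyl in place of chloro on an aromatic carbon. Going by the values given here, no measured pair shows this swap, so the expectation is only loosely founded. Compound 1, at 5.62%, leaves little room for a fall. The estimated step of a number 4.4 percentage points higher from compound 1 to compound 3 (within the scatter) is therefore a small rise, not expected to go beyond the scatter. For compound 3 the expected value is 10%, within an estimated range from 0% to 25%.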

Compound 3, percent growth inhibition at one concentration: 6.66%
Beside the measured number, compound 3's estimate is 3.3 percentage points above it; the range from low to high includes it.
By their numbers in this assay, from the lowest: compounds 1 and 3 (each within the scatter of the next); then compound 2.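

Putting tert-butyl in place of chloro on an aromatic carbon, para to a large group, gives in this assay a number 1 percentage points higher from compound 1 to compound 3 (within the scatter). Going by these compounds alone, this is the first direct reading of a change at this position, and it shows that this much larger all-carbon group and the single chlorine atom cannot be told apart in this read-out at the one concentration tested. Nothing available here explains this outcome.

Going by these compounds, whether a different kind of group at this position, such as an amine or a carboxylic acid, would give a step beyond the scatter remains open. A single pair also leaves open whether the same swap would read the same way on a different core.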